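The compounds below may be only part of what the source reports. "The series", "measured", "known", "first", "only" and "open" are said of these compounds alone.

Measured compounds in an assay on isolated protein for inhibition of protein kinase C zeta type (Homo sapiens), with stated times of 1 h and 2.5 min, tested at 30 uM; on this read-out higher numbers stand for more inhibition at the one concentration tested (going by the name of the read-out) and lower numbers for less inhibition:
- compound 1 `CCOC(=O)c1c(-c2ccc(OC)c(OC)c2)csc1NC`: 32%
- compound 2 `CCOC(=O)c1c(-c2ccc(OC)c(OC)c2)csc1N(C)C`: 60%
- compound 3 `COCC(C)OC(=O)c1c(-c2ccc(OC)c(OC)c2)csc1N`: 49%

Compound 3 stands second highest of the three numbers in this assay. Compound 2 gives 60%, so its number lies above that of compound 3 by more than the scatter, while compound 1 gives 32%, a number below compound 3 by more than the scatter. For the measured compounds named here, the one step that can be read between two measured compounds is a number 28 percentage points higher from compound 1 to compound 2 (beyond the scatter), a change on the nitrogen of the shared core.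

Compound 4 `COc1ccc(-c2csc(N)c2C(=O)OCc2ccc(C)cc2)cc1OC` differs from compound 3 at the ester side: 4-methylbenzyl in place of 1-(methoxymethyl)ethyl on an oxygen next to a carbonyl group. No measured pair changes that oxygen, so the single step shown, the one from compound 1 to compound 2, concerns another place on the core and bears on this change only as a sign that the read-out can move by a modest amount from one substituent change. Going by the values given here, with no direct precedent, the expectation for this assay is a step of no clear direction, likely within the scatter, written as a number 1 percentage points lower from compound 3 to compound 4 (within the scatter). Compound 4 is therefore estimated at 48%, with a range from 28% to 68%.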

Compound 4, a percentage reported as inhibition, at one concentration (the size of the read-out at that concentration, not a potency): 50%
Beside the measured number, compound 4's estimate is 2 percentage points below it; low and high end bracket the measured number.
By their numbers in this assay, from the lowest: compound 1; then compounds 3, 4 and 2 (each within the scatter of the next, the first and the last beyond it).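

In this assay, for the compounds shown here, placing 4-methylbenzyl instead of 1-(methoxymethyl)ethyl on the oxygen next to a carbonyl group gives a number 1 percentage points higher from compound 3 to compound 4 (within the scatter) and is the first step that can be read at this place. The earlier step showed the number moving beyond the scatter with a change on the nitrogen, whereas this one shows that a group with one six-membered aromatic ring of carbon only and no hydrogen-bond acceptor can replace a ringless group with one hydrogen-bond acceptor without a shift beyond the scatter, at least for this pair. Nothing measured here explains why the number stays within the scatter across this exchange.

Going by these compounds, whether a carboxylic acid, an amide or a longer chain at this place would leave the number within the scatter remains open, as does whether an unsubstituted benzyl would do so. On these data alone, it is also open whether the outcome at this oxygen would hold on a core carrying the two nitrogen methyl groups of compound 2, which gives 60% in this assay.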